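The source may report more compounds than this note shows. Statements on the series, on what has been measured and on what is new or still open speak of the compounds shown alone.

Compound 1 `COc1cc([C@@H]2C[C@]2(CO)C(=O)Nc2ccccc2Cl)cc(OC)c1OC`: 4400 nM
Compound 2 `COc1cc([C@H]2C[C@@]2(CO)C(=O)Nc2ccccc2)cc(OC)c1OC`: > 100000 nM (a limit)
Compound 3 `COc1cc([C@H]2C[C@]2(CO)C(=O)Nc2ccccc2Cl)cc(OC)c1OC`: 36700 nM

In a functional assay on A549 cells (Homo sapiens) for cytotoxicity, read by MTT assay, with a stated time of 48 h (on this read-out higher numbers stand for weaker inhibition and lower numbers for stronger inhibition), compound 3 gives the higher of the two actual numbers, 36700 nM. Compound 4 `COc1cc([C@H]2C[C@]2(CO)C(=O)Nc2ccccc2)cc(OC)c1OC` departs from compound 3 by hydrogen in place of chloro on an aromatic carbon. Among the measured compounds shown here, the only measured step, an 8.3-fold higher number from compound 1 to compound 3 (0.92 log units; beyond the scatter), reflects (the fact that compounds 1 and 3 differ only in the configuration as drawn), so it does not cover this change and gives no direct size for it. Compound 2, which also lacks the chloro, reaches only a limit of the assay, > 100000 nM. A modest move to a higher number is therefore expected, though this rests on thin evidence. The expected change is a 1.9-fold higher number from compound 3 to compound 4 (0.28 log units; within the scatter). For compound 4 the estimated value is 70000 nM, with an expected range of 30000 nM to 160000 nM.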

Compound 4, half-maximal inhibitory concentration: > 100000 nM
Compound 4: only a limit was reported; the forecaster's own chance of this, stated with the estimate: 50%; middle value at least 1.4-fold (0.15 log units) from the limit.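

Among the compounds shown here, replacing the chloro with hydrogen gives an at least 2.7-fold higher number from compound 3 to compound 4 (0.43 log units; beyond the scatter), the first measured step at this place on the aromatic ring, so in this configuration the 2-chlorophenyl group counts for more than the scatter. As far as these compounds go, the value of compound 4 is a limit, > 100000 nM, so the true size of the step remains unknown. The step between compound 2 and compound 4 cannot be read, since both compounds stand at the same limit: the limit of > 100000 nM in this assay, at which 2 of the 4 values shown sit.

From the compounds shown here alone, what a bromo or methoxy group at this place would give in this assay remains open. So does how far compound 2 and compound 4 lie past the limit.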